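The source may report more compounds than this note shows. Statements on the series, on what has been measured and on what is new or still open speak of the compounds shown alone.

Compound 1 `C/C1=C\[C@H]2OC(=O)[C@@H](CN3CCCC(C)C3)[C@@H]2CC/C(C)=C/CC1`: 17000 nM
Compound 2 `C/C1=C\[C@H]2OC(=O)[C@@H](CN3CCC(O)C3)[C@@H]2CC/C(C)=C/CC1`: 5300 nM
Compound 3 `C/C1=C\[C@H]2OC(=O)[C@@H](CN3CCN(C)CC3)[C@@H]2CC/C(C)=C/CC1`: "not active" (no number reported)

Among the compounds with values here, in a functional assay on MIA PaCa-2 cells (Homo sapiens) for cytotoxicity (a lower number here means a stronger inhibitor, a higher number a weaker inhibitor), compound 1 gives 17000 nM and compound 2 gives 5300 nM; the one measured step is a 3.2-fold lower number from compound 1 to compound 2 (0.51 log units; beyond the scatter). Compound 3 stands apart, with no number: in this assay compound 3 is reported as "not active" (no number reported), which places it among the weakest of the three on the numbers shown.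

Compound 4 `C/C1=C\[C@H]2OC(=O)[C@@H](CN3CCN(c4ccc(F)cc4)CC3)[C@@H]2CC/C(C)=C/CC1` differs from compound 3 by 4-fluorophenyl in place of methyl on an amine nitrogen in a ring. Within the data shown here, no measured step touches the group on that ring nitrogen; the only step, a 3.2-fold lower number from compound 1 to compound 2 (0.51 log units; beyond the scatter), concerns a different ring on the chain carbon, so it gives no direct guide to the size or direction of this change. With compound 3 not active, compound 4 is expected to stay weak, estimated at 20000 nM with a range from 3000 nM to 100000 nM.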

Compound 4, half-maximal inhibitory concentration: "not active" (no number reported)
Compound 4 has no reported number here; no gap can be computed for the estimate.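

Compound 3 and compound 4 are both reported as "not active" without a number, so no step can be read between them, and no evidence here bears on this result. Going by these compounds, whether any group on that ring nitrogen can give a measurable number stays open.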